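The source may hold more compounds than are shown below. What is called first, only, known or untested is meant among the compounds shown, and "the series" means these compounds.

Compound 1 `CC(C)(C)c1ccc(S(=O)(=O)N[C@H]2CCN(Cc3cc4[nH]cccc-4n3)C2=O)cc1` carries a 4-(tert-butyl)phenyl on the sulfonyl sulfur. In an assay on isolated protein for inhibition of coagulation factor X (Oryctolagus cuniculus), tested at 1 uM (a lower number here means less inhibition, a higher number more inhibition at the concentration tested (going by the name of the read-out)), compound 1 gives 22%, the second highest of the three numbers. Compound 2 `Cc1c(S(=O)(=O)N[C@H]2CCN(Cc3cc4c[nH]ccc-4n3)C2=O)sc2ccc(Cl)cc12` gives 37%, beyond the scatter above compound 1, while compound 3 `CC(C)(C)c1ccc(S(=O)(=O)N[C@H]2CCN(CCNc3ccncc3)C2=O)cc1` gives 14%, within the scatter of compound 1. Compound 4 `O=C1[C@@H](NS(=O)(=O)c2nc3cc(Cl)ccc3[nH]2)CCN1Cc1cc2[nH]cccc-2n1` is not yet measured and differs from compound 1 in one place: 5-chloro-1H-benzimidazol-2-yl in place of 4-(tert-butyl)phenyl on a sulfonyl sulfur. Going by the values given here, the only measured step, a number 8 percentage points lower from compound 1 to compound 3 (within the scatter), alters the group on the saturated chain carbon bound to the amide-type nitrogen in the ring and leaves the sulfonyl substituent untouched, so it does not bear on the change to compound 4. Compound 2 also differs from compound 1 at the sulfonyl sulfur, but it differs elsewhere as well, so its higher number cannot be assigned to one place. Among the compounds with values here, no measured step fixes the direction; a step within the scatter or beyond it, either way, remains open. For compound 4 the expected value is 28% with a range of 8% to 55%. The estimated step of a number 6 percentage points higher from compound 1 to compound 4 (within the scatter) is accordingly modest and carries wide uncertainty.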

Compound 4, a percentage reported as inhibition, at one concentration (the size of the read-out at that concentration, not a potency): 14%
Compound 4: middle estimate off by 14 percentage points, on the high side; the range from low to high includes it.
By their numbers in this assay, from the lowest: compounds 3, 4 and 1 (each within the scatter of the next); then compound 2.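

In this assay, going by these compounds alone, the first one-place change on the sulfonyl sulfur, 5-chloro-1H-benzimidazol-2-yl in place of 4-(tert-butyl)phenyl, gives a number 8 percentage points lower from compound 1 to compound 4 (within the scatter). At this position, then, a group with 1 hydrogen-bond donor and 1 hydrogen-bond acceptor replaces one with neither, and the number stays within the scatter. Nothing on hand accounts for this result.

Going by these compounds, compound 2 gives 37% but differs from compound 1 in more than one place, so how much of that number belongs to its sulfonyl substituent stays open. Also open, on these data alone, is how a plain methyl, or a phenyl carrying a carboxylic acid, would read on the same sulfonyl sulfur in this assay.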